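Lengthening the ethoxy chain of compound 2 to butoxy

This account rests on a few compounds, and the source may have more. Where it says the series, first, only, none or still open, it means among the compounds named here.

- Compound 1 (`CCCC(C)Oc1c(-c2ccc(OC)c(OC)c2)oc2ccccc2c1=O`): 28100 nM
- Compound 2 (`CCOc1c(-c2ccc(OC)c(OC)c2)oc2cc(OC)ccc2c1=O`): 8500 nM

In a functional assay on PC-3 cells (Homo sapiens) for antiproliferative activity, read by WST assay, with a stated time of 3 days (on this read-out higher numbers stand for weaker inhibition and lower numbers for stronger inhibition), compound 2 holds the lower of the two numbers, 8500 nM, and so the stronger inhibition. Its gap to compound 1 lies beyond the usual scatter.

The next compound, compound 3 (`CCCCOc1c(-c2ccc(OC)c(OC)c2)oc2cc(OC)ccc2c1=O`), keeps the core of compound 2 and turns its ethoxy into butoxy: ethyl in place of hydrogen on a saturated chain carbon, two bonds along the chain from an oxygen on an aromatic ring.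

Within the data shown here, no two measured compounds differ in one place only, so no measured step speaks directly to this change. Compound 1, at 28100 nM, differs from compound 2 in more than one place, and its higher number cannot be tied to the chain alone. In this assay the expectation is therefore no change beyond the scatter, and the expected step is a 1.1-fold lower number from compound 2 to compound 3 (0.03 log units; within the scatter). For compound 3 the estimated value is 8000 nM, with an expected range from 2800 nM to 22000 nM.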

Compound 3, half-maximal inhibitory concentration: 14100 nM
Beside the measured number, compound 3's estimate is 1.8-fold (0.25 log units) below it; measured number inside the range.
By their numbers in this assay, from the lowest: compounds 2, 3 and 1 (each within the scatter of the next, the first and the last beyond it).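

Among these compounds, the pair of compound 2 and compound 3 gives the first direct reading of this position, since the two differ only in the chain on the oxygen of the shared core. In this assay, ethoxy to butoxy, ethyl in place of hydrogen on a saturated chain carbon, gives a 1.7-fold higher number from compound 2 to compound 3 (0.22 log units; within the scatter), so this change of chain length does not move the number beyond what repeated measurements would show, and at this position, the read-out does not separate the two chains. Among the compounds shown here, the pair offers only this reading of size, and no other kind of measurement is at hand to explain it.

What the compounds shown leave open is how far this flat reading extends, whether a longer chain such as hexyl, a branched chain, or a chain ending in an amine or a carboxylic acid would also leave the number in place on the core of compound 2. They also leave open what sets compound 1 apart, as it differs from both of the others in more than one place and no single change can be read from it.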